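The source may hold more compounds than are shown below. What is called first, only, known or untested is meant among the compounds shown, and "the series" means these compounds.

Measured so far in a functional assay on SW-620 cells (Homo sapiens) for antiproliferative activity, read by MTT assay, with a stated time of 24 h; a lower number here means a stronger inhibitor, a higher number a weaker inhibitor:
Compound 1 `COc1ccc(C(=O)/C=C/c2ccc(F)cc2)c2c1C=CC(C)(C)O2`: > 10000 nM
Compound 2 `COc1ccc(C(=O)/C=C/c2ccc(-c3ccccc3)cc2)c2c1C=CC(C)(C)O2`: > 10000 nM
Compound 3 `COc1ccc(C(=O)/C=C/c2ccc(N(c3ccccc3)c3ccccc3)cc2)c2c1C=CC(C)(C)O2`: > 10000 nM

For the measured compounds named here, the series so far shows (the limit of > 10000 nM in this assay, at which 3 of the 3 values shown sit). Compound 2 stands at > 10000 nM, which is a limit of the assay and not a number, so it cannot be ranked against the other compounds.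

The next compound is compound 4 `COc1ccc(C(=O)/C=C/c2ccc(N3CCCC3)cc2)c2c1C=CC(C)(C)O2`, which differs from compound 2 as follows: pyrrolidin-1-yl in place of phenyl on an aromatic carbon. In short, pyrrolidin-1-yl stands in place of phenyl on an aromatic carbon. Going by the values given here, one measured step bears on this same carbon: a step that the two limits leave unreadable from compound 1 to compound 2. It offers no size and no direction to carry over. Among the compounds with values here, compound 3, the only measured compound with nitrogen in that substituent, gives > 10000 nM, again a limit, and it is the nearest guide here.

Because of the limit of > 10000 nM in this assay, at which 3 of the 3 values shown sit, no step beyond the scatter is expected in this assay, although the data cannot exclude a readable number for compound 4. The expected change is a number no higher from compound 2 to compound 4 (the limit leaves the size open). Compound 4 is estimated at 10000 nM, with an expected range of 3000 nM to 30000 nM.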

Compound 4, half-maximal inhibitory concentration: 7150 nM
Compound 4: middle estimate off by 1.4-fold (0.15 log units), on the high side; the range from low to high includes it.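

In this assay, compound 4 gives the only readable number in the series, so this aromatic carbon, para to a large group, can carry a substituent that brings the read-out inside the measured range, while the other compounds stay at the limit: the limit of > 10000 nM in this assay, at which 3 of the 4 values shown sit.

Pyrrolidin-1-yl gives an at least 1.3-fold lower number from compound 2 to compound 4 (0.14 log units; that floor lies within the scatter) when it replaces phenyl, and an at least 1.3-fold lower number from compound 1 to compound 4 (0.14 log units; that floor lies within the scatter) when it replaces fluoro; both are floors, so the true size of each change stays open. Nitrogen in the substituent on this carbon is not enough on its own for a readable number, as compound 3 gives > 10000 nM, which is a limit.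

The compounds shown do not separate the contribution of the nitrogen from that of the saturated ring, a question that piperidin-1-yl, morpholin-4-yl or an open-chain dimethylamino group on the same carbon would address. They also leave open whether a carboxylic acid or a primary amine at this place would give a readable number in this assay.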